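Cyclopropylcarbonyl amide in the hexafluorocarbinol naphthylamide series

This account rests on a few compounds, and the source may have more. Where it says the series, first, only, none or still open, it means among the compounds named here.

Compound 3 `CC(C)=CC(=O)Nc1c(C(O)(C(F)(F)F)C(F)(F)F)ccc2ccccc12` gives 550 nM in a functional assay (Sus scrofa) with sulfonylurea receptors; K-ATP channels (Homo sapiens) as the target (on this read-out lower numbers stand for an effect already at smaller amounts and higher numbers for an effect only at larger amounts of compound), the highest number of the three measured. Compound 1 `CC(=O)Nc1c(C(O)(C(F)(F)F)C(F)(F)F)ccc2ccccc12` gives 95.5 nM and compound 2 `CCC(=O)Nc1c(C(O)(C(F)(F)F)C(F)(F)F)ccc2ccccc12` gives 8.91 nM; since a 5.8-fold higher number from compound 1 to compound 3 (0.76 log units; beyond the scatter) and a 62-fold higher number from compound 2 to compound 3 (1.79 log units; beyond the scatter) both lie beyond the scatter, compound 3 is the weakest of the three in this assay. The next compound, compound 4 `O=C(Nc1c(C(O)(C(F)(F)F)C(F)(F)F)ccc2ccccc12)C1CC1`, carries the change (cyclopropyl in place of 2-methylprop-1-en-1-yl on a carbonyl carbon).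

The relevant measured steps run in the opposite direction from the one considered here: a 62-fold higher number from compound 2 to compound 3 (1.79 log units; beyond the scatter) and a 5.8-fold higher number from compound 1 to compound 3 (0.76 log units; beyond the scatter) show that the 2-methylprop-1-en-1-yl group on the carbonyl carbon gives clearly higher numbers than either ethyl or methyl, and an 11-fold lower number from compound 1 to compound 2 (1.03 log units; beyond the scatter) shows that among the small saturated groups the slightly larger one gives the lower number. Cyclopropyl removes the double bond and brings the group back toward the size of ethyl, so a large step downward in this assay is expected for compound 4, landing near the numbers of compound 1 and compound 2. Compound 4 is expected to give about 20 nM in this assay, within a range from 4 nM to 120 nM. The expected step is a 28-fold lower number from compound 3 to compound 4 (1.44 log units; beyond the scatter).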

Compound 4, half-maximal effective concentration: 126 nM
Compound 4: middle estimate off by 6.3-fold (0.80 log units), on the low side, and the stated range ends below it.
By their numbers in this assay, from the lowest: compound 2; then compounds 1 and 4 (each within the scatter of the next); then compound 3.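

In this assay the swap of 2-methylprop-1-en-1-yl for cyclopropyl on the carbonyl carbon gives a 4.4-fold lower number from compound 3 to compound 4 (0.64 log units; beyond the scatter) and so recovers only part of the ground, while the swap of ethyl for cyclopropyl gives a 14-fold higher number from compound 2 to compound 4 (1.15 log units; beyond the scatter) and shows that the ring does not share the low number of compound 2. Cyclopropyl and methyl cannot be told apart at this position, with a 1.3-fold higher number from compound 1 to compound 4 (0.12 log units; within the scatter) as the step between them, so among the four groups on the carbonyl carbon ethyl alone reaches the lowest number. Nothing available gives a reason for the gap between ethyl and cyclopropyl.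

On these data alone, whether n-propyl or isopropyl on the carbonyl carbon keeps the low number of compound 2 remains open. Also open, as far as these compounds go, is whether cyclobutyl would differ from cyclopropyl.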